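Moving Fluorine on the Amide Ring of an mGlu5 Modulator

The compounds below may be only part of what the source reports. "The series", "measured", "known", "first", "only" and "open" are said of these compounds alone.

Measured compounds:
- compound 1, `O=C(c1ccc(F)cc1)N1CCc2nc(COc3cccnc3)oc2C1`: 40%
- compound 2, `O=C(c1cccc(F)c1F)N1CCc2nc(COc3cccc(F)c3)oc2C1`: 72%

Both compounds were tested in a functional assay on HEK293 cells for positive allosteric modulation of metabotropic glutamate receptor 5 (Homo sapiens), read by calcium flux; on this read-out lower numbers stand for smaller maximal responses and higher numbers for larger maximal responses. Compound 1 gives 40%, while compound 2 gives 72%. Of the two numbers recorded so far, compound 2 stands highest; its nearest neighbour is compound 1, whose value lies well below it, a gap that exceeds the usual scatter. Among the compounds with values here, the two compounds differ in more than one place, so no single step between them can be traced.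

Compound 3, `O=C(c1c(F)cccc1F)N1CCc2nc(COc3cccc(F)c3)oc2C1`, has not yet been measured. It differs from compound 2 in one place: 2,6-difluorophenyl in place of 2,3-difluorophenyl on a carbonyl carbon. The same atoms are present, only joined differently, so the change is a rearrangement rather than an addition or loss.

Within the data shown here, no measured pair shows what such a rearrangement does to the largest response, so the expectation rests on compound 2 alone. Compound 3 is estimated to give 62%, within a range from 38% to 86%. That estimate means a step from compound 2 to compound 3 of a number 10 percentage points lower from compound 2 to compound 3 (within the scatter), expected to stay close to the scatter, with a slight lean downward.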

Compound 3, largest response reached (reported as percent of maximum), in percent of the reference or control that the assay uses: 82%
Compound 3: the middle estimate sits 20 percentage points below what was measured; the measured number falls inside the stated range.
By their numbers in this assay, from the lowest: compound 1; then compounds 2 and 3 (each within the scatter of the next).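

In this assay, within the data shown here, the change of 2,6-difluorophenyl in place of 2,3-difluorophenyl on a carbonyl carbon gives a number 10 percentage points higher from compound 2 to compound 3 (within the scatter) and is the first comparison here that differs in one place only. It shows that, at this position, the two fluorines can be rearranged without a change that this read-out can separate from ordinary scatter, so compound 2 and compound 3 cannot be told apart by their maximal responses. No measurement shown here offers an explanation for how these two arrangements relate to the response.

The steps that would link compound 1 to the other two compounds cannot be read, as it differs from each of them in more than one place, so the part played by each of those differences remains unresolved. From the compounds shown here alone, it also remains open whether this position would accept other groups on the carbonyl carbon, such as an unsubstituted phenyl, 2,6-dichlorophenyl or 2-methoxyphenyl, and so whether the fluorines themselves matter to the response at all.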